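The source may hold more compounds than are shown below. What is called first, only, known or untested is meant among the compounds shown, and "the series" means these compounds.

Compound 1 `COc1cc(/C=N/c2c(C#N)ncn2-c2ccc(F)cc2)cc(OC)c1OC` and compound 2 `N#Cc1ncn(-c2ccc(F)cc2)c1/N=C/c1ccc([N+](=O)[O-])cc1` share a core and differ in the group attached to it; the difference between the two cores is not broken down here. In a functional assay on A549 cells (Homo sapiens) for antiproliferative activity, read by MTT assay, with a stated time of 48 h (on this read-out lower numbers stand for stronger inhibition and higher numbers for weaker inhibition), compound 1 gives 9880 nM, and in this assay compound 2 gives 18100 nM, so the two values lie within the scatter of each other. Compound 3 `COc1cc(/C=N/c2c(C#N)ncn2Cc2ccc(F)cc2)cc(OC)c1OC` arises from compound 1 by a single change, (4-fluorobenzyl in place of 4-fluorophenyl on an aromatic nitrogen), and in this assay compound 3 gives 9710 nM. The step was a 1.0-fold lower number from compound 1 to compound 3 (0.01 log units; within the scatter), a result indistinguishable from no change at all. Compound 4 `N#Cc1ncn(Cc2ccc(F)cc2)c1/N=C/c1ccc([N+](=O)[O-])cc1` stands to compound 2 as compound 3 stands to compound 1: the change is 4-fluorobenzyl in place of 4-fluorophenyl on an aromatic nitrogen, at a place described in exactly the same words, so it is the same change on the other core. Compound 4 is expected to show a 1.1-fold lower number from compound 2 to compound 4 (0.03 log units; within the scatter), because a 1.0-fold lower number from compound 1 to compound 3 (0.01 log units; within the scatter) was flat on the core of compound 1. The estimate for compound 4 in this assay is therefore 17000 nM, with a likely range from 7000 nM to 40000 nM.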

Compound 4, half-maximal inhibitory concentration: 2020 nM
For compound 4 the middle estimate is 8.4-fold (0.93 log units) above the measured one; the whole stated range lies above it.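

On the other core, replacing 4-fluorophenyl with 4-fluorobenzyl on the aromatic nitrogen gave a 9.0-fold lower number from compound 2 to compound 4 (0.95 log units; beyond the scatter) in this assay. The same change therefore did not carry over at the same size from one core to the other: the same change on two cores in this assay, a 1.0-fold lower number (0.01 log units; within the scatter) from compound 1 to compound 3 and a 9.0-fold lower number (0.95 log units; beyond the scatter) from compound 2 to compound 4, 8.8-fold (0.94 log units) apart, beyond the scatter of two such steps. This shows that, within these two pairs, the size of the step depends on the core that carries it, but with a single pair on each core it does not show which feature of the cores is responsible or how the change would behave on any further core.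

The compounds shown leave open whether a longer chain between the aromatic nitrogen and the 4-fluorophenyl ring would extend the step seen on the core of compound 4 or lose it. They also leave open whether that step would survive if the nitro group of compound 4 gave way to an amine or a carboxylic acid.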